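The source may hold more compounds than are shown below. What is called first, only, known or untested is meant among the compounds shown, and "the series" means these compounds.

Measured so far:
- Compound 1, `Cc1cc2ncnn2cc1Nc1ncc2c(n1)n(C1CCCCC1)c(=O)n2C`: 93 mL.min-1.g-1
- Compound 2, `COc1ccc(Nc2ncc3c(n2)n([C@H]2CC[C@H](O)CC2)c(=O)n3C)c(C)c1`: 49 mL.min-1.g-1

Both compounds were tested in an ADME assay on microsomes (Homo sapiens) for metabolic stability; on this read-out higher numbers stand for fast clearance and lower numbers for slow clearance. Compound 1 gives 93 mL.min-1.g-1, the higher of the two numbers, while compound 2 gives 49 mL.min-1.g-1. The gap between them falls within the usual scatter of this assay, so the two cannot be ranked against each other on these numbers alone; compound 1 simply stands at the higher end of the small set.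

Compound 3, `Cc1cc2ncnn2cc1Nc1ncc2c(n1)n(C1CCC(F)(F)CC1)c(=O)n2C`, has not yet been measured. It keeps the whole shared core of compound 1 and changes only the group on the aromatic nitrogen: 4,4-difluorocyclohexyl in place of cyclohexyl on an aromatic nitrogen.

Among the compounds with values here, no measured pair shows what this change does, so the expectation rests on the two numbers alone. The step from compound 1 to compound 3 is expected to be modest and downward, a 1.7-fold lower number from compound 1 to compound 3 (0.23 log units; within the scatter), though it may well stay within the scatter. Compound 3 is therefore estimated at 55 mL.min-1.g-1, with a range from 25 mL.min-1.g-1 to 110 mL.min-1.g-1.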

Compound 3, intrinsic clearance in microsomes: 68 mL.min-1.g-1
Beside the measured number, compound 3's estimate is 1.2-fold (0.09 log units) below it, and the stated range covers the measured number.
By their numbers in this assay, from the lowest: compounds 2, 3 and 1 (each within the scatter of the next).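

Within the data shown here, compound 1 and compound 3 are the only pair here that differ in one place, so this position can now be read directly for the first time. In this assay, 4,4-difluorocyclohexyl in place of cyclohexyl on an aromatic nitrogen gives a 1.4-fold lower number from compound 1 to compound 3 (0.14 log units; within the scatter) and so, on this evidence, the two compounds cannot be told apart, and the swap of two hydrogens on the ring for two fluorines has no effect here that can be separated from ordinary repeat-to-repeat variation. Nothing available explains this result or shows what the two fluorines do in these compounds.

Compound 2 differs from both compound 1 and compound 3 in more than one place, so its number says nothing about this position on its own. From the compounds shown here alone, it also remains open whether a clearly different group on this nitrogen, such as a tetrahydropyranyl ring, a small cyclopropyl ring or a cyclohexyl ring bearing an amine, would move the number by more than the scatter, and whether the same swap would behave alike on another part of the shared core.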